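Swapping chlorines for fluorines on a chalcone-pyrazole

The source may report more compounds than this note shows. Statements on the series, on what has been measured and on what is new or still open speak of the compounds shown alone.

Measured so far:
compound 1 `COc1ccc(-c2cc(/C=C/C(=O)c3ccc(N)cc3)[nH]n2)cc1` gives 95%
compound 2 `COc1cc(-c2cc(/C=C/C(=O)c3ccc(Cl)c(Cl)c3)[nH]n2)cc(OC)c1OC` gives 106%

Going by the values given here, in a functional assay on K562 cells (Homo sapiens) for cytotoxicity, read by sulforhodamine B assay, with a stated time of 48 h, tested at 0.1 uM (on this read-out lower numbers stand for a stronger effect and higher numbers for a weaker effect at the one concentration tested), compound 2 gives 106%, the highest of the two numbers, and its only neighbour, compound 1, sits a number of points lower, beyond the scatter. Compound 3 `COc1cc(-c2cc(/C=C/C(=O)c3ccc(F)c(F)c3)[nH]n2)cc(OC)c1OC` is not yet measured. It differs from compound 2 by 3,4-difluorophenyl in place of 3,4-dichlorophenyl on a carbonyl carbon. Among the compounds with values here, no measured step of this kind exists here, so the expected step is judged from the change alone: a small one, in either direction, likely not beyond the scatter, which is what a number 6 percentage points lower from compound 2 to compound 3 (within the scatter) is estimated to be. Compound 3 is expected to give about 100%, between 85% and 115%.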

Compound 3, a percentage reported as activity, at one concentration (the size of the read-out at that concentration, not a potency): 109%
Compound 3: the middle estimate sits 9 percentage points below what was measured; low and high end bracket the measured number.
By their numbers in this assay, from the lowest: compound 1; then compounds 2 and 3 (each within the scatter of the next).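

In this assay, putting 3,4-difluorophenyl in place of 3,4-dichlorophenyl on a carbonyl carbon gives a number 3 percentage points higher from compound 2 to compound 3 (within the scatter). This first one-place comparison shows that, at this single concentration, the read-out does not separate the two halogen pairs at this position. No supporting measurement is available to explain this outcome.

On these data alone, whether a quite different group here, such as a carboxylic acid or a nitrile, would separate from these two remains open. So does whether compound 2 and compound 3 would stay together at other concentrations.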